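Swapping methoxy for methyl: a second test of the same step

The source may report more compounds than this note shows. Statements on the series, on what has been measured and on what is new or still open speak of the compounds shown alone.

Measured so far:
Compound 1 `Cc1cc(CN(C2CCC2)C(CC(=O)O)c2ccc(Cl)cc2)ccc1OCCn1c(=O)ccn(C)c1=O`: 20%
Compound 2 `COc1cc(CN(C2CCC2)C(CC(=O)O)c2ccc(Cl)cc2)ccc1OCCn1c(=O)ccn(C)c1=O`: 61%
Compound 3 `COc1cc(CN(CC(C)C)C(CC(=O)O)c2ccc(Cl)c(F)c2)ccc1OCCN1C(=O)CCC1=O`: 76%

In an ADME assay on liver (Homo sapiens) for metabolic stability, read by LC-MS, using microsomes and NADPH (a higher number here means that more of the compound is left, a lower number that less of the compound is left), compound 3 gives 76%, the highest of the three. Compound 1 and compound 2 share a core, and between them one change was made, (methyl in place of methoxy on an aromatic carbon); that step was a number 41 percentage points lower from compound 2 to compound 1 (beyond the scatter). Compound 4 `Cc1cc(CN(CC(C)C)C(CC(=O)O)c2ccc(Cl)c(F)c2)ccc1OCCN1C(=O)CCC1=O` is not yet measured. It arises from compound 3 by methyl in place of methoxy on an aromatic carbon, the same kind of change, though here the place is ortho to a 2-(2,5-dioxopyrrolidin-1-yl)ethoxy group rather than ortho to a large group. The difference between the core of compound 3 and the core of compound 2 is not broken down here. Because the earlier step was a number 41 percentage points lower from compound 2 to compound 1 (beyond the scatter), a drop of similar size is expected for compound 4, estimated as a number 36 percentage points lower from compound 3 to compound 4 (beyond the scatter). Compound 4 is thus expected to give about 40%, likely between 20% and 62%.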

Compound 4, percent of the compound remaining: 63%
Compound 4: the middle estimate sits 23 percentage points below what was measured, outside the stated range (above it).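

In this assay, methyl in place of methoxy gives a number 13 percentage points lower from compound 3 to compound 4 (beyond the scatter), so the step points the same way on both cores shown, but two pairs cannot establish a rule for the whole series. Its size does not carry over from one core to the other: the same change on two cores in this assay, a number 41 percentage points lower (beyond the scatter) from compound 2 to compound 1 and a number 13 percentage points lower (beyond the scatter) from compound 3 to compound 4, 28 percentage points apart, beyond the scatter of two such steps The two cores differ in more than one place, and these pairs do not show which of those differences goes with the smaller step.

Still open, on these data alone, is how an ethoxy group or a chlorine atom would read in the place of the methoxy group. Also open, as far as these compounds go, is how the same swap would read on a third core.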